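A few compounds are considered here, and "the series" means these few. Any claim that something is new, unique, unknown or untested is made for them only; others in the source may bear on it.

Compound 1 `CCC(C)NC(=C\C(=O)/C=C/c1ccc(O)c(OC)c1)/C=C/c1ccc(O)c(OC)c1`: > 25000 nM
Compound 2 `C=CCNC(=C\C(=O)/C=C/c1ccc(O)c(OC)c1)/C=C/c1ccc(O)c(OC)c1`: > 25000 nM
Compound 3 `COc1cc(/C=C/C(=O)/C=C(/C=C/c2ccc(O)c(OC)c2)NC2CCCCC2)ccc1O`: > 25000 nM

Compound 3 gives > 25000 nM in an ADME assay on Caco-2 cells (Homo sapiens) for inhibition, read by MTT assay, with a stated time of 72 h (on this read-out higher numbers stand for weaker inhibition and lower numbers for stronger inhibition), and this is a limit of the assay, not a number. Going by the values given here, the series so far shows the limit of > 25000 nM in this assay, at which 3 of the 3 values shown sit, with no actual number among the three.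

Compound 4 `COc1cc(/C=C/C(=O)/C=C(/C=C/c2ccc(O)c(OC)c2)NCC(C)C)ccc1O` changes one group: isobutyl in place of cyclohexyl on an amine nitrogen in short, isobutyl in place of cyclohexyl on an amine nitrogen. The measured steps on that nitrogen are a step that the two limits leave unreadable from compound 1 to compound 2 and a step that the two limits leave unreadable from compound 1 to compound 3 and a step that the two limits leave unreadable from compound 2 to compound 3 so no size or direction can be read from them, and no step beyond the usual scatter is expected in this assay for this change. The expected move is a step that the limit leaves unreadable from compound 3 to compound 4 and another limit is the likeliest report. Compound 4 is estimated at 35000 nM with an expected range from 15000 nM to 80000 nM overall.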

Compound 4, half-maximal inhibitory concentration: > 25000 nM
Compound 4: no number, only a limit; the forecaster's own chance of this, stated with the estimate: 85%; the middle value is on the limit's open side.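

Compound 4 adds no readable step: its steps from compound 1, compound 2 and compound 3 each join two limits, not numbers, and cannot be read. The compounds shown leave open whether the group on the amine nitrogen changes inhibition at all.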